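The source may hold more compounds than are shown below. What is called first, only, known or untested is meant among the compounds shown, and "the series" means these compounds.

In a functional assay on K562 cells (Homo sapiens), read by MTT assay, with a stated time of 72 h (a higher number here means a weaker inhibitor, a lower number a stronger inhibitor), compound 1 `C#Cc1cn([C@@H]2O[C@H](CO)[C@@H](O)[C@H]2O)c2ncnc(OC)c12` gives 380 nM, while compound 2 `CNc1ncnc2c1c(-c1ccco1)cn2[C@@H]1O[C@H](CO)[C@@H](O)[C@H]1O` gives 15100 nM. Compound 2 has the higher of the two numbers, making it the weaker inhibitor by a gap beyond the scatter. Compound 3 `CNc1ncnc2c1c(-c1cc3ccccc3o1)cn2[C@@H]1O[C@H](CO)[C@@H](O)[C@H]1O` has not yet been measured. It carries 1-benzofuran-2-yl in place of furan-2-yl on an aromatic carbon of the core of compound 2: 1-benzofuran-2-yl in place of furan-2-yl on an aromatic carbon. Within the data shown here, no measured pair shows what this swap does, so no change beyond the scatter is expected, with an estimated 1.3-fold lower number from compound 2 to compound 3 (0.10 log units; within the scatter). In this assay, the estimate for compound 3 is 12000 nM, with an expected range of 3000 nM to 45000 nM.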

Compound 3, half-maximal inhibitory concentration: > 20000 nM
Compound 3 was reported as a limit (the forecaster's own chance of this, stated with the estimate: 30%); middle value at least 1.6-fold (0.22 log units) away from the limit.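

In this assay, compound 3 is reported as a limit, not as a number: the limit of > 20000 nM in this assay, at which 1 of the 3 values shown sits. The swap from furan-2-yl to 1-benzofuran-2-yl on this aromatic carbon can therefore be read in one direction only, as an at least 1.3-fold higher number from compound 2 to compound 3 (0.12 log units; that floor lies within the scatter). The added six-membered aromatic ring shows no gain in inhibition at this position, while the true size of the step stays hidden. From the compounds shown here alone, it remains open how far compound 3 lies past the limit. Going by these compounds, it is also open how a phenyl ring or a simple amine would fare on this same carbon.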